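This account rests on a few compounds, and the source may have more. Where it says the series, first, only, none or still open, it means among the compounds named here.

Measured compounds in a functional assay on MDA-MB-231 cells (Homo sapiens) for cytotoxicity, read by MTT assay, with a stated time of 72 h; a higher number here means a weaker inhibitor, a lower number a stronger inhibitor:
compound 1 `FC(F)(F)c1ccc(CSc2nc(N3CCCCC3)c3ccccc3n2)cc1` gives 28400 nM.
compound 2 `FC(F)(F)c1ccc(CSc2nc(Nc3cccc(C(F)(F)F)c3)c3ccccc3n2)cc1` gives 11100 nM.
compound 3 `COc1ccc(Nc2nc(SCc3ccc(C(F)(F)F)cc3)nc3ccccc23)c(OC)c1` gives only a limit, > 50000 nM.

Compound 3 therefore stands at the edge of this assay: its value is a limit, not a number, and it sits at the limit of > 50000 nM in this assay, at which 1 of the 3 values shown sits. Within the set, compound 2 is the most potent, since both a 2.6-fold lower number from compound 1 to compound 2 (0.41 log units; beyond the scatter) and an at least 4.5-fold higher number from compound 2 to compound 3 (0.65 log units; beyond the scatter) are beyond the scatter. The step of an at least 1.7-fold higher number from compound 1 to compound 3 (0.24 log units; that floor lies within the scatter) has a floor that lies within the scatter, so compound 1 and compound 3 cannot be ordered against each other on what is shown.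

Compound 4 `COc1ccc(Nc2nc(SCc3ccc(C(F)(F)F)cc3)nc3ccccc23)cc1OC` is reached from compound 3 by a single change: 3,4-dimethoxyphenyl in place of 2,4-dimethoxyphenyl on a nitrogen on an aromatic ring. For the measured compounds named here, none of the measured steps touches this kind of change; each of them exchanges the whole group on the nitrogen of the shared core for a different one, as in a 2.6-fold lower number from compound 1 to compound 2 (0.41 log units; beyond the scatter) and an at least 4.5-fold higher number from compound 2 to compound 3 (0.65 log units; beyond the scatter), rather than moving a methoxy group around the same ring. Going by the values given here, with no bearing step, no movement beyond the scatter is expected in this assay, and a result at the limit remains the most likely outcome. Compound 4 is therefore estimated at 50000 nM, with a range of 20000 nM to 120000 nM; the step of a number no higher from compound 3 to compound 4 (the limit leaves the size open) expresses that expectation.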

Compound 4, half-maximal inhibitory concentration: 18900 nM
Estimate against measurement, compound 4: 2.6-fold (0.42 log units) above, outside the stated range (below it).
By their numbers in this assay, from the lowest: compounds 2, 4 and 1 (each within the scatter of the next, the first and the last beyond it). At a limit, above all of these: compound 3.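

In this assay, for the compounds shown here, moving a methoxy group around the same ring, with the atoms unchanged, gives an at least 2.6-fold lower number from compound 3 to compound 4 (0.42 log units; beyond the scatter), whereas the earlier steps exchanged the whole group on the nitrogen; at this position, the arrangement on the ring therefore matters as well as the identity of the group. Compound 3 remains at a limit, so this step has only a floor and its full size stays open: the limit of > 50000 nM in this assay, at which 1 of the 4 values shown sits.

The 3,4-dimethoxyphenyl group of compound 4 cannot be separated from the groups in the two other compounds with numerical values, as a 1.7-fold higher number from compound 2 to compound 4 (0.23 log units; within the scatter) and a 1.5-fold lower number from compound 1 to compound 4 (0.18 log units; within the scatter) show, so among these three the group on that carbon gives no order involving compound 4.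

Going by these compounds alone, it remains open whether the step follows from the one methoxy group that changes place or from the two-methoxy arrangement as a whole; a phenyl ring carrying a single methoxy group on the same nitrogen would bear on this. Going by these compounds, all four compounds also share the group on sulfur, so the effect of a carboxylic acid or a nitrile on that ring in place of trifluoromethyl remains unknown.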